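From compound 3 to compound 4: estimating past a limit

A few compounds are considered here, and "the series" means these few. Any claim that something is new, unique, unknown or untested is made for them only; others in the source may bear on it.

Values in an ADME assay on microsomes from liver (Rattus norvegicus) for metabolic stability; on this read-out lower numbers stand for a shorter-lived compound and higher numbers for a longer-lived compound:
- Compound 1 `Nc1nc(NCCNc2ncc(-c3ncc[nH]3)c(-c3ccc(F)cc3F)n2)ccc1[N+](=O)[O-]`: > 0.5 h (a limit)
- Compound 2 `Nc1nc(NCCNc2ncc(-c3ncc[nH]3)c(-c3cc(F)ccc3Cl)n2)ccc1[N+](=O)[O-]`: > 0.5 h (a limit)
- Compound 3 `Nc1nc(NCCNc2ncc(-c3ncc[nH]3)c(-c3cc(F)c(Cl)cc3Cl)n2)ccc1[N+](=O)[O-]`: > 0.5 h (a limit)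

Compound 3 gives > 0.5 h, which is a limit and not a number. The whole set shares this position: the limit of > 0.5 h in this assay, at which 3 of the 3 values shown sit. Compound 4 `Cc1ccc(-c2nc(NCCNc3ccc([N+](=O)[O-])c(N)n3)ncc2-c2ncc[nH]2)c(Br)c1` differs in one group, with 2-bromo-4-methylphenyl in place of 2,4-dichloro-5-fluorophenyl (2-bromo-4-methylphenyl in place of 2,4-dichloro-5-fluorophenyl on an aromatic carbon). The nearest evidence is a step that the two limits leave unreadable from compound 1 to compound 3 and a step that the two limits leave unreadable from compound 2 to compound 3, with a step that the two limits leave unreadable from compound 1 to compound 2 alongside. None of these has a readable size, so they point in no direction. The expected step is therefore a step that the limit leaves unreadable from compound 3 to compound 4, with nothing expected beyond the scatter. Compound 4 is estimated at 0.8 h, with an expected range of 0.4 h to 1.6 h.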

Compound 4, half-life: > 0.5 h
Compound 4: no number, only a limit; the forecaster's own chance of this, stated with the estimate: 80%; the middle value is on the limit's open side.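

The result for compound 4 is again a limit, not a number, so its steps from compound 1, compound 2 and compound 3 cannot be read. How long each of these compounds actually lasts in this assay, and whether they differ at all, stays open: the limit of > 0.5 h in this assay, at which 4 of the 4 values shown sit.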